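A few compounds are considered here, and "the series" means these few. Any claim that something is new, unique, unknown or untested is made for them only; others in the source may bear on it.

Compound 2 `O=C(O)CCCSCCN1C(=O)OC[C@@H]1/C=C/[C@@H](O)Cc1ccccc1` is a short-chain acid whose side chain ends in a plain benzyl group. In an assay on CHO cells for displacement of a labelled ligand from prostaglandin E2 receptor EP3 subtype (Mus musculus), read by scintillation counting, with a stated time of 60 min (a lower number here means a stronger inhibitor, a higher number a weaker inhibitor), compound 2 gives 6400 nM. Of the two plain numbers shown, that is the higher one: compound 3 `CCCc1cccc(C[C@H](O)/C=C/[C@H]2CCC(=S)N2CCCCCCC(=O)O)c1`, built on a different core, gives 2000 nM in this assay, a gap beyond the usual scatter of repeated measurements. Compound 1 `COCc1cccc(C[C@H](O)/C=C/[C@H]2CSC(=O)N2CCSCCCC(=O)O)c1` reaches only the limit of this assay, reported as > 10000 nM and not as a number (the limit of > 10000 nM in this assay, at which 1 of the 3 values shown sits).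

Compound 4 `O=C(O)CCCSCCN1C(=O)OC[C@@H]1/C=C/[C@@H](O)Cc1cccc(Cl)c1` differs from compound 2 in one place: chloro in place of hydrogen on an aromatic carbon. No pair of measured compounds among these three shows a change of that kind, so there is no direct precedent here for the size or direction of the step. The expectation is a modest move toward a lower number, at the edge of the scatter rather than far beyond it, with the step from compound 2 to compound 4 estimated at a 2.1-fold lower number from compound 2 to compound 4 (0.33 log units; beyond the scatter) in this assay.

On that basis compound 4 is expected to give about 3000 nM in this assay, with a likely range from 1000 nM to 9000 nM.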

Compound 4, inhibition constant: 630 nM
For compound 4 the middle estimate is 4.8-fold (0.68 log units) above the measured one, and the stated range ends above it.
By their numbers in this assay, from the lowest: compound 4; then compound 3; then compound 2. At a limit, above all of these: compound 1.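

Going by these compounds alone, this pair gives the first direct reading of a change on the aromatic ring of the benzyl group, and that ring turns out not to be indifferent in this assay: chloro in place of hydrogen gives a 10-fold lower number from compound 2 to compound 4 (1.01 log units; beyond the scatter), a large step beyond the usual scatter. The change adds just one heavy atom, with no ring, no hydrogen-bond donors or acceptors and no net charge, so a very small edit on this aromatic carbon, meta to a large group, can move the number a long way. No measurement shown here bears on why the number falls at this position.

The compounds shown leave open whether this step belongs to chloro itself or would also come with another group on the same carbon, such as fluoro, a methyl group or a methoxy group. They also leave open whether chloro would give a step of this size on a different core, such as the core of compound 3, or on another carbon of the same aromatic ring.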